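The source may report more compounds than this note shows. Statements on the series, on what has been measured and on what is new or still open speak of the compounds shown alone.

Compound 1 `Cc1ccc(-n2nc(C(=O)Nc3ccc(Oc4ncnc5ccsc45)cc3)c(C)cc2=O)cc1` and compound 2 `Cc1ccc(-n2nc(C(=O)Nc3ccc(Oc4ncnc5ccsc45)c(F)c3)c(C)cc2=O)cc1` share one core and differ in a single place: fluoro in place of hydrogen on an aromatic carbon. In a functional assay on MCF7 cells (Homo sapiens) for cytotoxicity, read by MTT assay, with a stated time of 72 h (a lower number here means a stronger inhibitor, a higher number a weaker inhibitor), compound 1 gives 23800 nM, while compound 2 gives 7250 nM, so the change made a 3.3-fold lower number from compound 1 to compound 2 (0.52 log units; beyond the scatter). Compound 3 `Cc1cc(=O)n(-c2ccc(F)cc2)nc1C(=O)Nc1ccc(Oc2ncnc3sccc23)c(F)c1` is built on a different core; how the two cores differ is not broken down here. In this assay compound 3 gives 12300 nM. Compound 4 `Cc1cc(=O)n(-c2ccc(F)c(F)c2)nc1C(=O)Nc1ccc(Oc2ncnc3sccc23)c(F)c1` has not yet been measured and differs from compound 3 by fluoro in place of hydrogen on an aromatic carbon. For the measured compounds named here, this is the same kind of change as the one from compound 1 to compound 2, but the surroundings are not identical: in compound 2 the fluorine sits ortho to a large group and meta to a large group, whereas in compound 4 it sits ortho to a fluoro group and meta to a large group. Because the earlier step was a 3.3-fold lower number from compound 1 to compound 2 (0.52 log units; beyond the scatter), a somewhat smaller gain is expected here, namely a 1.5-fold lower number from compound 3 to compound 4 (0.19 log units; within the scatter). Compound 4 is therefore expected to give about 8000 nM, between 3500 nM and 20000 nM.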

Compound 4, half-maximal inhibitory concentration: 20600 nM
The estimate for compound 4 lay 2.6-fold (0.41 log units) below the measured number; the measured number lies above the stated range.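

Putting fluoro in place of hydrogen on an aromatic carbon, here 4-fluorophenyl to 3,4-difluorophenyl, gave a 1.7-fold higher number from compound 3 to compound 4 (0.22 log units; within the scatter) in this assay, a step too small to count as a real change. The clear gain seen on the other core therefore did not carry over, and the two steps do differ: the same change on two cores in this assay, a 3.3-fold lower number (0.52 log units; beyond the scatter) from compound 1 to compound 2 and a 1.7-fold higher number (0.22 log units; within the scatter) from compound 3 to compound 4, 5.5-fold (0.74 log units) apart, beyond the scatter of two such steps. This shows that the result of this change on one core cannot simply be assumed on another in this series, but it does not show why, as the two cores differ, the two fluorines have different surroundings, and a single pair per core gives no general rule.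

On these data alone, it remains open how a chloro, a methoxy or an amine in place of the new fluoro would behave on the core of compound 3. As far as these compounds go, it is also open whether any of these groups would give a step beyond the scatter.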